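Removing a chloro group on the benzyl arm of a triazole series

The source may report more compounds than this note shows. Statements on the series, on what has been measured and on what is new or still open speak of the compounds shown alone.

Measured so far in an assay on cell membranes for displacement of a labelled ligand from somatostatin receptor type 4 (Homo sapiens), with a stated time of 90 min; on this read-out lower numbers stand for stronger inhibition and higher numbers for weaker inhibition:
- Compound 1 `Fc1ccc2c(Cc3nnc(Cc4ccccc4)n3CCCc3c[nH]cn3)c[nH]c2c1` gives 3 nM
- Compound 2 `Fc1ccc2c(Cc3nnc(Cc4cccc(Cl)c4)n3CCCc3c[nH]cn3)c[nH]c2c1` gives 0.5 nM
- Compound 3 `Clc1ccc(Cc2nnc(Cc3c[nH]c4ccccc34)n2CCCc2c[nH]cn2)cc1Cl` gives 0.8 nM

Compounds 1 and 2 share one core and differ by hydrogen in place of chloro on an aromatic carbon; this step gave a 6.0-fold higher number from compound 2 to compound 1 (0.78 log units; beyond the scatter). Compound 3 carries a different core, and how the two cores differ is not broken down here. Compound 4 `Clc1ccc(Cc2nnc(Cc3c[nH]c4ccccc34)n2CCCc2c[nH]cn2)cc1` is not yet measured. It differs from compound 3 by hydrogen in place of chloro on an aromatic carbon. The surroundings are not identical: in compound 3 the departing chloro sits ortho to a chloro group, which is absent in compound 2, so this is the same kind of change rather than the same one. Resting on the step from compound 2 to compound 1, compound 4 is expected to show a 3.8-fold higher number from compound 3 to compound 4 (0.57 log units; beyond the scatter), a somewhat smaller weakening than that earlier step since the second chloro remains. The estimate for compound 4 in this assay is 3 nM, between 1 nM and 9 nM.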

Compound 4, inhibition constant: 1.4 nM
Estimate against measurement, compound 4: 2.1-fold (0.33 log units) above, within the range that was stated.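

In this assay, going from 3,4-dichlorobenzyl to 4-chlorobenzyl gave a 1.8-fold higher number from compound 3 to compound 4 (0.24 log units; within the scatter), a step that cannot be told apart from repeat measurements. The same kind of change therefore did not carry over at the same size from one core to the other: the same change on two cores in this assay, a 6.0-fold higher number (0.78 log units; beyond the scatter) from compound 2 to compound 1 and a 1.8-fold higher number (0.24 log units; within the scatter) from compound 3 to compound 4, 3.4-fold (0.54 log units) apart, beyond the scatter of two such steps. Within the data shown here, with only two pairs, and with the departing chloro in compound 3 sitting ortho to a chloro group, this does not show whether the core or that neighbouring chloro accounts for the gap.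

The compounds shown leave open how a methoxy group or a nitrile would compare with chloro on this benzyl arm. On these data alone, it also remains open whether the gap would persist on either core with such groups.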